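The compounds below may be only part of what the source reports. "The series", "measured", "known", "first", "only" and "open" are said of these compounds alone.

Within the data shown here, compound 2 `O=C(CCl)Nc1ccc(-c2nc3cc(C(F)(F)F)ccc3[nH]2)cc1` has the lower of the two numbers measured so far in an ADME assay on MDBK cells (Bos taurus) for cytotoxicity, read by MTT assay, with a stated time of 96 h (a lower number here means that less compound is tolerated, a higher number that more compound is tolerated), where compound 2 gives 17000 nM. Compound 1 `O=C(CN1CCCCC1)Nc1ccc(-c2nc3ccccc3[nH]2)cc1` gives 18000 nM in this assay, and the gap between the two lies within the scatter. Compound 3 `O=C(CN1CCCCC1)Nc1ccc(-c2nc3cc(C(F)(F)F)ccc3[nH]2)cc1` has not yet been measured. It differs from compound 2 by piperidin-1-yl in place of chloro on a saturated chain carbon bound to a carbonyl carbon. Because compound 1 already carries the piperidin-1-yl and gives 18000 nM, no step beyond the scatter is expected. The expected step is a 1.1-fold higher number from compound 2 to compound 3 (0.02 log units; within the scatter). Compound 3 is estimated to give 18000 nM, with a range from 8000 nM to 40000 nM.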

Compound 3, half-maximal cytotoxic concentration: 6000 nM
Compound 3: the middle estimate sits 3.0-fold (0.48 log units) above what was measured; the measured number lies below the stated range.
By their numbers in this assay, from the lowest: compound 3; then compounds 2 and 1 (each within the scatter of the next).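

In this assay the group on the saturated chain carbon bound to a carbonyl carbon matters: piperidin-1-yl in place of chloro gives a 2.8-fold lower number from compound 2 to compound 3 (0.45 log units; beyond the scatter) and so less compound is tolerated. Trifluoromethyl in place of hydrogen on an aromatic carbon gives a 3.0-fold lower number from compound 1 to compound 3 (0.48 log units; beyond the scatter) in the same direction, so piperidin-1-yl alone does not set the number. Nothing available explains either step.

As far as these compounds go, both steps end at compound 3, so it remains open whether either holds elsewhere. A different amine, such as morpholin-4-yl or dimethylamino, might behave differently at the chain carbon, as might chloro or fluoro in place of trifluoromethyl.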